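Methyl on the saturated ring and cytotoxicity

A few compounds are considered here, and "the series" means these few. Any claim that something is new, unique, unknown or untested is made for them only; others in the source may bear on it.

Compound 1 `Cc1ccc(O)c(C(=O)NCCCN2CCC[C@@H]3CCCC[C@@H]32)c1` gives > 100 ug/mL in a functional assay on MDBK cells (Bos taurus) for cytotoxicity (on this read-out lower numbers stand for higher toxicity in this test and higher numbers for lower toxicity in this test), which is a limit of the test rather than a number.
Compound 2 `Cc1ccc(O)c(C(=O)NCCCN2CC(C)C[C@@H]3CCCC[C@@H]32)c1` gives 9.5 ug/mL in this assay.
Compound 3 `Cc1ccc(O)c(C(=O)NCCCN2CCC[C@@H]3CCCC[C@H]32)c1` gives 60 ug/mL in this assay.

Compound 1 and compound 3 share the same atoms and bonds; their cores differ only as drawn: the two compounds have the same atoms and bonds and differ only in configuration as drawn: 1 of 2 stereo elements differ; a stereocentre at a saturated ring carbon is drawn S in compound 1 and R in compound 3. The step of an at least 1.6-fold lower number from compound 1 to compound 3 (0.22 log units; that floor lies within the scatter). From compound 1 to compound 2 the change is methyl in place of hydrogen on a saturated ring carbon, and it made an at least 10-fold lower number from compound 1 to compound 2 (1.02 log units; beyond the scatter); this size rests on the limit (the limit of > 100 ug/mL in this assay, at which 1 of the 3 values shown sits).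

Compound 4 `Cc1ccc(O)c(C(=O)NCCCN2[C@@H]3CCCC[C@H]3CC[C@@H]2C)c1` is not yet measured. From compound 3 it carries methyl in place of hydrogen on a saturated ring carbon. This is the same kind of change as from compound 1 to compound 2, not the same: here the methyl sits next to the ring nitrogen and next to the ring atom that bears a large group, whereas before it sat two ring bonds from each. Guided by the step of an at least 10-fold lower number from compound 1 to compound 2 (1.02 log units; beyond the scatter), a lower number is expected, roughly a 4.0-fold lower number from compound 3 to compound 4 (0.60 log units; beyond the scatter). Compound 4 is estimated at 15 ug/mL, between 5 ug/mL and 50 ug/mL.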

Compound 4, half-maximal cytotoxic concentration: 30 ug/mL
For compound 4 the middle estimate is 2.0-fold (0.30 log units) below the measured one, within the range that was stated.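

In this assay, methyl in place of hydrogen on a saturated ring carbon gives a 2.0-fold lower number from compound 3 to compound 4 (0.30 log units; within the scatter), so this pair cannot be told apart in this test. Set beside the earlier step, the change does not carry over at one size from core to core: the same change on two cores in this assay, an at least 10-fold lower number (1.02 log units; beyond the scatter) from compound 1 to compound 2 and a 2.0-fold lower number (0.30 log units; within the scatter) from compound 3 to compound 4, at least 5.2-fold (0.72 log units) apart, beyond the scatter of two such steps

This does not show whether the ring place of the methyl or the drawn configuration of the core sets that gap, and the size of the earlier step rests on a limit of the test: the limit of > 100 ug/mL in this assay, at which 1 of the 4 values shown sits.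

The compounds shown leave open what methyl does at each ring place on each drawn configuration. They also leave open whether an ethyl or a hydroxyl on the same ring carbon would follow methyl.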